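The source may hold more compounds than are shown below. What is called first, only, known or untested is meant among the compounds shown, and "the series" means these compounds.

Compound 1 `COc1cccc(NC(=N)Nc2cccc(OC)c2)c1` gives 351 nM in an assay on membranes from brain (Cavia porcellus) for binding affinity to Sigma non-opioid intracellular receptor 1 (Homo sapiens), read by radioligand binding; on this read-out lower numbers stand for stronger inhibition and higher numbers for weaker inhibition. Compound 2 `Cc1ccccc1NC(=N)N(C)c1ccccc1C` gives 6280 nM. Compound 3 `CN(C(=N)Nc1cccc2ccccc12)c1cccc2ccccc12` gives 4800 nM.

Among these three numbers compound 3 stands second highest; its nearest neighbour is compound 2, whose number lies within the scatter of it, while compound 1 lies well beyond the scatter with the lowest number of the set. Compound 4 `N=C(Nc1cccc2ccccc12)N(c1ccccc1)c1cccc2ccccc12` is the next compound, not yet measured in this assay. It differs from compound 3 by phenyl in place of methyl on a nitrogen on an aromatic ring. Among the compounds with values here, no measured pair shows this change, so its size is not known here. Compound 4 is expected to give 2500 nM, between 800 nM and 8000 nM, which would mean an estimated step of a 1.9-fold lower number from compound 3 to compound 4 (0.28 log units; within the scatter) toward a lower number, of a size near the edge of the scatter.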

Compound 4, half-maximal inhibitory concentration: 7930 nM
Compound 4: the middle estimate sits 3.2-fold (0.50 log units) below what was measured; low and high end bracket the measured number.
By their numbers in this assay, from the lowest: compound 1; then compounds 3, 2 and 4 (each within the scatter of the next).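

Phenyl in place of methyl on this nitrogen on an aromatic ring, which brings six heavy atoms and a six-membered aromatic ring where one carbon stood, gives a 1.7-fold higher number from compound 3 to compound 4 (0.22 log units; within the scatter) in this assay. This first reading of the position shows that this exchange leaves the number within the scatter when both other aromatic groups stay the same. Nothing available explains this outcome.

Going by these compounds, whether a benzyl group or a longer chain on this nitrogen would read alike remains open. So does whether the same exchange would give a similar step on the core of compound 2.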